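The source may hold more compounds than are shown below. What is called first, only, known or untested is meant among the compounds shown, and "the series" means these compounds.

Compound 1, `N[C@@H](C(=O)O)[C@H]1CC(O)=NO1`, sets the starting point. In a functional assay on CHO cells with metabotropic glutamate receptor 2 (Rattus norvegicus) as the target, read by cAMP accumulation (on this read-out higher numbers stand for an effect only at larger amounts of compound and lower numbers for an effect already at smaller amounts), compound 1 gives only a limit of the assay, > 1000000 nM, and no number. Its companion compound 2, `N[C@H](C(=O)O)[C@H]1CC(O)=NO1`, shares every atom and bond with compound 1 and differs from it in configuration alone; in this assay compound 2 gives 84000 nM; 83200 nM (2 entries), a figure that rests on (the several entries of compound 2 in this assay, 84000 nM; 83200 nM (2 entries)), while compound 1 stands at the limit of > 1000000 nM in this assay, at which 1 of the 2 values shown sits. That the two differ only by the fact that compounds 1 and 2 differ only in the configuration as drawn shows how much the drawn configuration can matter here.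

The step from compound 1 to compound 3, `N[C@H](C(=O)O)[C@@H]1CC(O)=NO1`, is again one of configuration only: the two compounds have the same atoms and bonds and differ only in configuration as drawn: 2 of 2 stereo elements differ (all stereocentres are inverted: mirror images); a stereocentre at a saturated chain carbon is drawn R in compound 1 and S in compound 3; a stereocentre at a saturated ring carbon is drawn R in compound 1 and S in compound 3. Among the measured compounds shown here, with no measured step of this exact kind to lean on, the direction is uncertain, but a move from a limit into a measurable range would not be surprising. The expected step from compound 1 to compound 3 in this assay is an at least 6.6-fold lower number from compound 1 to compound 3 (0.82 log units; beyond the scatter). Compound 3 is therefore estimated at 150000 nM, within a range of 20000 nM to 1000000 nM.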

Compound 3, half-maximal effective concentration: > 1000000 nM
Compound 3: no number, only a limit (the forecaster's own chance of this, stated with the estimate: 35%); at least 6.6-fold (0.82 log units) between middle value and limit.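

Compound 1 and compound 3, which are mirror images, both give only a limit in this assay, so the step between them cannot be read. The compounds shown leave open how far each lies beyond that limit, and whether the two differ at all.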